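The compounds below may be only part of what the source reports. "The series", "measured", "known", "first", "only" and "open" are said of these compounds alone.

Measured compounds in this series:

compound 1, `C[C@@H]1CN(c2nnc(Cc3ccccc3)c3cc(C(F)(F)F)ccc23)CCN1c1ccc(C#N)cn1`, 12000 nM
compound 2, `C[C@@H]1CN(c2nnc(Cc3ccccc3)c3ccc(C(F)(F)F)cc23)CCN1c1ccc(C#N)cn1`, 100 nM
compound 3, `C[C@@H]1CN(c2nnc(Cc3ccccc3)c3cc(C#N)ccc23)CCN1c1ccc(C#N)cn1`, 1300 nM

All three were run in an assay on Sf9 cells for inhibition of sphingosine-1-phosphate lyase 1 (Homo sapiens), with a stated time of 1 h; on this read-out higher numbers stand for weaker inhibition and lower numbers for stronger inhibition. Compound 1 and compound 2 share the same atoms joined differently; the difference between the two cores is not broken down here. Compound 2 gives the lowest number of the three, and its gaps to compound 3 and compound 1 both lie beyond the scatter.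

One change is seen once so far: cyano in place of trifluoromethyl on an aromatic carbon, which gave a 9.2-fold lower number from compound 1 to compound 3 (0.97 log units; beyond the scatter). The same kind of change leads from compound 2 to compound 4, `C[C@@H]1CN(c2nnc(Cc3ccccc3)c3ccc(C#N)cc23)CCN1c1ccc(C#N)cn1`, as cyano in place of trifluoromethyl on an aromatic carbon. The two place descriptions are the same word for word, so the change sits in an equivalent position on each core.

Going by the values given here, for compound 4 the expectation is a step of about a 5.0-fold lower number from compound 2 to compound 4 (0.70 log units; beyond the scatter), resting on the single measured step of a 9.2-fold lower number from compound 1 to compound 3 (0.97 log units; beyond the scatter), but tempered because compound 1 gives 12000 nM, far from that of compound 2, and that step was seen only on the core of compound 1. Compound 4 is therefore estimated at 20 nM, with a range from 5 nM to 80 nM.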

Compound 4, half-maximal inhibitory concentration: 24 nM
Compound 4: middle estimate off by 1.2-fold (0.08 log units), on the low side; the measured number falls inside the stated range.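

In this assay, cyano in place of trifluoromethyl on an aromatic carbon gives a 4.2-fold lower number from compound 2 to compound 4 (0.62 log units; beyond the scatter) on the second core, the same direction as on the core of compound 1. Set side by side, the two steps cannot be told apart in size: the same change on two cores in this assay, a 9.2-fold lower number (0.97 log units; beyond the scatter) from compound 1 to compound 3 and a 4.2-fold lower number (0.62 log units; beyond the scatter) from compound 2 to compound 4, 2.2-fold (0.35 log units) apart, within the scatter of two such steps. Going by these compounds alone, the change therefore carries across these two cores, even though compound 1 and compound 2 start far apart, but this rests on only two matched pairs in one assay, and it neither shows that the change would carry to any further core nor explains why the number falls.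

Still open, as far as these compounds go, is how other groups would read at this aromatic carbon, for example chlorine, an amine, a carboxylic acid or a longer chain such as ethoxy. Also open, from the compounds shown here alone, is whether the cyano step holds when the benzyl-free parts of the molecule, such as the methyl on the shared core, are altered.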